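From 2,4-Dichlorophenyl to 4-Methylphenyl in a Cytotoxic Series

This account rests on a few compounds, and the source may have more. Where it says the series, first, only, none or still open, it means among the compounds named here.

Of the compounds shown here, three sharing one core have been measured in a functional assay on cells (Tumor Cell line, Homo sapiens) for cytotoxicity; on this read-out lower numbers stand for stronger inhibition and higher numbers for weaker inhibition. Compound 1 `CN(C)Cc1cc(C(=O)/C=C/c2ccccc2)cc(CN(C)C)c1O`, which carries a phenyl group, gives 21900 nM. Compound 2 `CN(C)Cc1cc(C(=O)/C=C/c2ccccc2Cl)cc(CN(C)C)c1O` gives 9550 nM. Compound 3 `CN(C)Cc1cc(C(=O)/C=C/c2ccc(Cl)cc2Cl)cc(CN(C)C)c1O` gives 3090 nM, the lowest number of the three.

Compound 4 `Cc1ccc(/C=C/C(=O)c2cc(CN(C)C)c(O)c(CN(C)C)c2)cc1` differs from compound 3 in one place, on a double-bonded chain carbon bound to a double-bonded chain carbon, where 4-methylphenyl stands in place of 2,4-dichlorophenyl: 4-methylphenyl in place of 2,4-dichlorophenyl on a double-bonded chain carbon bound to a double-bonded chain carbon.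

Among the compounds with values here, three measured steps bear on this change. The first chloro gave a 2.3-fold lower number from compound 1 to compound 2 (0.36 log units; beyond the scatter), and the second gave a 3.1-fold lower number from compound 2 to compound 3 (0.49 log units; beyond the scatter). Taken together, the 2,4-dichlorophenyl group gave a 7.1-fold lower number from compound 1 to compound 3 (0.85 log units; beyond the scatter). Compound 4 has neither chloro, so this modest gain is not expected to carry over in full. Within the data shown here, no measured compound carries a methyl group, and the data therefore do not show what it contributes. A partial return towards compound 1 seems the most reasonable expectation, leaving compound 4 between the two ends of the series in this assay. The expected change is a 3.9-fold higher number from compound 3 to compound 4 (0.59 log units; beyond the scatter), a move to a higher number and so to weaker inhibition. For compound 4 the estimate is 12000 nM, with an expected range from 5000 nM to 28000 nM.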

Compound 4, half-maximal inhibitory concentration: 17800 nM
The estimate for compound 4 lay 1.5-fold (0.17 log units) below the measured number; measured number inside the range.
By their numbers in this assay, from the lowest: compound 3; then compounds 2, 4 and 1 (each within the scatter of the next, the first and the last beyond it).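

In this assay, 4-methylphenyl does not retain the gain seen with 2,4-dichlorophenyl, giving a 5.8-fold higher number from compound 3 to compound 4 (0.76 log units; beyond the scatter), so at this place on a double-bonded chain carbon the lower number of compound 3 does not carry over to a group with a methyl and neither chloro. Within the data shown here, the methyl itself, which the earlier compounds could not address, shows no effect beyond the scatter, with a 1.2-fold lower number from compound 1 to compound 4 (0.09 log units; within the scatter), and the exchange of 2-chlorophenyl for 4-methylphenyl, at a 1.9-fold higher number from compound 2 to compound 4 (0.27 log units; within the scatter), also stays within the scatter, so compound 4 cannot be separated from either compound 1 or compound 2. Nothing available here accounts for this difference between the 2,4-dichlorophenyl and 4-methylphenyl groups.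

The compounds shown leave open whether a bromo, methoxy or nitrile group on this aromatic ring would stay near compound 3 or near compound 4. They also leave open whether the same order would hold if another amine, such as morpholine, replaced the dimethylamino groups of the shared core.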